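The source may hold more compounds than are shown below. What is called first, only, known or untested is meant among the compounds shown, and "the series" means these compounds.

Measured so far in a physicochemical assay for lipophilicity, read by HPLC, measured as chromatographic lipophilicity, at pH 7.4; on this read-out higher numbers stand for higher lipophilicity and lower numbers for lower lipophilicity:

Compound 1 `O=C(C1CCCCC1)N1N=CCC1c1ccccc1`: 5.9
Compound 2 `CC(C)(C)C(=O)N1N=CCC1c1cc(F)cc(F)c1`: 6.3
Compound 3 `CC(C)(C)C(=O)N1N=CCC1c1ccncc1`: 3.2

Compound 1 stands second highest of the three numbers in this assay. Its nearest neighbour is compound 2, whose value lies higher by an amount beyond the scatter; the furthest is compound 3, whose value lies well lower, again beyond the scatter. Within the data shown here, the three compounds differ from one another in more than one place, so no single step between measured compounds is available to calibrate the change under consideration.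

Compound 4 `O=C(C1CCOC1)N1N=CCC1c1ccccc1` shares the core of compound 1 and differs from it only on the carbonyl carbon: oxolan-3-yl in place of cyclohexyl on a carbonyl carbon

Among the measured compounds shown here, no measured pair isolates this exchange. Going from compound 1 to compound 4, the expectation is a decrease in this assay that is clearly beyond the scatter, as the estimated step of a number 1.80 log units lower from compound 1 to compound 4 (beyond the scatter) states. The value of compound 4 in this assay is estimated at 4.1, with a range from 3.3 to 4.9. The reading of compound 4 is then expected to fall between the values of compound 3 and compound 1, closer to compound 1.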

Compound 4, distribution coefficient: 3
Compound 4: middle estimate off by 1.10 log units, on the high side, outside the stated range (below it).
By their numbers in this assay, from the lowest: compounds 4 and 3 (each within the scatter of the next); then compound 1; then compound 2.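

At the position on a carbonyl carbon whose other neighbours are an amide-type nitrogen in a ring, oxolan-3-yl in place of cyclohexyl gives, in this assay, a large change: a number 2.90 log units lower from compound 1 to compound 4 (beyond the scatter). Among these compounds, the earlier compounds differ from one another in more than one place, so this is the first step that can be assigned to a single position, and it shows that this position alone can move the read-out well beyond the scatter with the rest of compound 1 unchanged. The exchange alters several counted features at once, going from a six-membered ring of carbon only to a five-membered ring with 1 hetero atom and from 0 to 1 hydrogen-bond acceptor, and no available data bear on which of these accounts for the size of the step.

Among the compounds shown here, the single step cannot separate ring size from the ring oxygen; cyclopentyl and oxan-4-yl on the same carbonyl carbon would divide it between the two. As far as these compounds go, it also remains open whether an exchange of this size carries over to a shared core bearing a different aryl group, such as the difluorophenyl ring of compound 2.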